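This account rests on a few compounds, and the source may have more. Where it says the series, first, only, none or still open, it means among the compounds named here.

Measured compounds in a functional assay on MDA-MB-231 cells (Homo sapiens) for cytotoxicity, read by MTT assay, with a stated time of 72 h; on this read-out lower numbers stand for stronger inhibition and higher numbers for weaker inhibition:
compound 1, `FC(F)(F)c1ccc(CSc2nc(Nc3cccc(C(F)(F)F)c3)c3ccccc3n2)cc1`: 11100 nM
compound 2, `Cc1ccc(Nc2nc(SCc3ccc(C(F)(F)F)cc3)nc3ccccc23)cc1`: > 50000 nM, which is a limit of the assay and not a number

Compound 2 stands at the limit of > 50000 nM in this assay, at which 1 of the 2 values shown sits, in this assay, so its position is known only as a limit. Within the data shown here, the one measured step, an at least 4.5-fold higher number from compound 1 to compound 2 (0.65 log units; beyond the scatter), shows that exchanging the aryl group on the nitrogen on the aromatic ring already moved the read-out beyond the scatter, and in the direction of weaker inhibition.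

Compound 3, `COc1ccc(Nc2nc(SCc3ccc(C(F)(F)F)cc3)nc3ccccc23)c(OC)c1`, is not yet measured in this assay. It differs from compound 2 by 2,4-dimethoxyphenyl in place of 4-methylphenyl on a nitrogen on an aromatic ring. Among the measured compounds shown here, the only measured step that bears on this position is an at least 4.5-fold higher number from compound 1 to compound 2 (0.65 log units; beyond the scatter); it says the group on this nitrogen matters, but nothing measured tells in which direction 2,4-dimethoxyphenyl moves the read-out, and compound 2 offers only a limit as the starting point. The expectation for compound 3 is therefore a weak value near that limit, with a step of an at least 1.1-fold lower number from compound 2 to compound 3 (0.04 log units; that floor lies within the scatter) expected to stay within the scatter. Compound 3 is estimated at 45000 nM, range 15000 nM to 150000 nM.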

Compound 3, half-maximal inhibitory concentration: > 50000 nM
Compound 3 ended at the assay's limit; the forecaster's own chance of this, stated with the estimate: 45%; middle value at least 1.1-fold (0.04 log units) away from the limit.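

In this assay, 2,4-dimethoxyphenyl in place of 3-(trifluoromethyl)phenyl gives an at least 4.5-fold higher number from compound 1 to compound 3 (0.65 log units; beyond the scatter), which points the same way as the earlier exchange, an at least 4.5-fold higher number from compound 1 to compound 2 (0.65 log units; beyond the scatter). So a second, differently substituted aryl group on this nitrogen also fails to keep the reading of compound 1, and the earlier loss is no longer tied to 4-methylphenyl alone. The step between compound 2 and compound 3 cannot be read, and 4-methylphenyl and 2,4-dimethoxyphenyl cannot be ordered, leaving compound 1 as the only one of the three with a value that is a number rather than a limit: the limit of > 50000 nM in this assay, at which 2 of the 3 values shown sit.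

Still open, on these data alone, is whether the reading of compound 1 depends on the trifluoromethyl group itself or would persist with a nitrile or a chlorine in its place on that phenyl ring, and whether a non-aromatic amine such as morpholine would be tolerated on the core. The group on the sulfur is the same in all three compounds, so nothing here tells how a longer alkyl chain or a plain benzyl group there would read.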